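Trimming the anilino ring of compound 1

This account rests on a few compounds, and the source may have more. Where it says the series, first, only, none or still open, it means among the compounds named here.

Measured compounds:
compound 1, `Cc1ccc(NC2=CC(=O)c3c(nc4n3[C@H]3OC[C@@H](O)[C@H]3OC4)C2=O)cc1C`, 1050 nM
compound 2, `O=C1C=C(NC2CCCC2)C(=O)c2c1nc1n2[C@H]2OC[C@@H](O)[C@H]2OC1`, > 8000 nM

In a functional assay on MGC-803 cells (Homo sapiens) for inhibition, read by sulforhodamine B assay (on this read-out higher numbers stand for weaker inhibition and lower numbers for stronger inhibition), compound 1 gives 1050 nM. Within the data shown here, it is the only compound of the set with a number; compound 2 stands at a limit of the assay, > 8000 nM, which is the case described by the limit of > 8000 nM in this assay, at which 1 of the 2 values shown sits. Compound 1 therefore has no measured neighbour to set a scale for the step now considered.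

Compound 3, `O=C1C(Nc2ccccc2)=CC(=O)c2c1nc1n2[C@H]2OC[C@@H](O)[C@H]2OC1`, is not yet measured. It differs from compound 1 by phenyl in place of 3,4-dimethylphenyl on an amine nitrogen. Among the measured compounds shown here, no step between measured compounds covers this change, so its size has to be guessed. The plain anilino ring is expected to sit a little weaker than the dimethyl-bearing ring, so the step from compound 1 to compound 3 in this assay is expected to be modest, a 2.4-fold higher number from compound 1 to compound 3 (0.38 log units; beyond the scatter), towards weaker inhibition. Compound 3 is expected to give about 2500 nM, within 900 nM to 7000 nM.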

Compound 3, half-maximal inhibitory concentration: 1830 nM
For compound 3 the middle estimate is 1.4-fold (0.14 log units) above the measured one; the range from low to high includes it.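

In this assay, replacing 3,4-dimethylphenyl with phenyl on the amine nitrogen amounts to a 1.7-fold higher number from compound 1 to compound 3 (0.24 log units; within the scatter), a change that cannot be told apart from repeat measurement. This gives compound 1 its first measured neighbour and shows that, at this position, the anilino ring keeps its reading without the two methyl groups. Nothing measured here gives a cause for this result.

Going by these compounds, it remains open whether a single methyl group, a methoxy group or a chlorine on the phenyl ring, or a pyridine ring in place of it, would move the number beyond the scatter. Compound 2 stands at a limit of the assay and differs from compound 3 in more than one place, so it provides no step for this position: the limit of > 8000 nM in this assay, at which 1 of the 3 values shown sits.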